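The compounds below may be only part of what the source reports. "The series", "measured", "known", "first", "only" and "open" are said of these compounds alone.

Compound 3 `Nc1ccn(COCCO)c(=O)n1` carries an amino group on the shared core. In a functional assay on L1210 cells (Mus musculus) for inhibition (on this read-out lower numbers stand for stronger inhibition and higher numbers for weaker inhibition), compound 3 gives > 1000 ug/mL, which is a limit of the assay rather than a measured number. Its two relatives stand no differently. Compound 1 `O=c1ccn(COCCO)c(=O)[nH]1` gives > 1000 ug/mL, again a limit. Compound 2 `O=c1[nH]c(=O)n(COCCO)cc1[N+](=O)[O-]` gives > 1000 ug/mL, also a limit. Going by the values given here, the only measured step between neighbouring structures, a step that the two limits leave unreadable from compound 1 to compound 2, cannot be read for size, since both of its ends sit at a limit (the limit of > 1000 ug/mL in this assay, at which 3 of the 3 values shown sit).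

Compound 4 `Nc1nc(=O)n(COCCO)cc1[N+](=O)[O-]` differs from compound 3 in one place: nitro in place of hydrogen on an aromatic carbon. The same kind of change, nitro in place of hydrogen on an aromatic carbon, separates compound 1 from compound 2, and there it left both values at the limit. The step expected here is a number no higher from compound 3 to compound 4 (the limit leaves the size open). Compound 4 is expected to remain at the limit as well. The estimate for compound 4 in this assay is 1000 ug/mL, in a range from 300 ug/mL to 3000 ug/mL.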

Compound 4, concentration for 50% inhibition: 374 ug/mL
Compound 4: middle estimate off by 2.7-fold (0.43 log units), on the high side, and the stated range covers the measured number.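

In this assay, going by these compounds alone, nitro in place of hydrogen on an aromatic carbon now gives an at least 2.6-fold lower number from compound 3 to compound 4 (0.42 log units; beyond the scatter), so this change at this position can be read for the first time. Compound 4 carries the amino group as well as the nitro group, and it is the only compound shown with a true number rather than a limit. Compound 2 has the nitro group without the amino group and gave no readable step, so here the nitro group lowers the number only in the compound that also carries the amino group.

On these data alone, whether another group at this position, such as bromine or a nitrile, would also lower the number remains open. The full size of the step is open too, since it starts from a limit: the limit of > 1000 ug/mL in this assay, at which 3 of the 4 values shown sit.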